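The source may report more compounds than this note shows. Statements on the series, on what has been measured and on what is new or still open speak of the compounds shown alone.

Two measured members of the series share one core. Compound 1 `C=C(C(=O)c1ccc(OC)cc1)C(OC(=O)c1ccccc1)c1ccc([N+](=O)[O-])cc1` carries a 4-nitrophenyl on the saturated chain carbon, and in a functional assay on MCF7 cells (Homo sapiens) for inhibition, read by XTT assay, with a stated time of 48 h (a higher number here means a weaker inhibitor, a lower number a stronger inhibitor), compound 1 gives 56100 nM. Compound 2 `C=C(C(=O)c1ccc(OC)cc1)C(OC(=O)c1ccccc1)c1ccccc1[N+](=O)[O-]` carries a 2-nitrophenyl at the same place, and in this assay compound 2 gives 11800 nM. For the measured compounds named here, the single step so far, a 4.8-fold lower number from compound 1 to compound 2 (0.68 log units; beyond the scatter), leaves compound 2 with the lowest of the two numbers, with compound 1 as its only neighbour.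

Compound 3 `C=C(C(=O)c1ccc(OC)cc1)C(OC(=O)c1ccccc1)c1ccc([N+](=O)[O-])cc1[N+](=O)[O-]` is the next step: nitro in place of hydrogen on an aromatic carbon, so the ring now carries two nitro groups. Going by the values given here, no measured pair adds a second nitro to a ring that already has one; the step from compound 1 to compound 2 only exchanges the position of a single nitro and bears on the question indirectly. With the 4-nitro pattern of compound 1 giving the higher number, a change in this assay of modest size, more likely toward a higher number, is expected, on the order of a 1.4-fold higher number from compound 2 to compound 3 (0.13 log units; within the scatter). Compound 3 is accordingly estimated at 16000 nM, in a range from 5000 nM to 50000 nM.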

Compound 3, half-maximal inhibitory concentration: > 100000 nM
Compound 3: only a limit was reported; the forecaster's own chance of this, stated with the estimate: 10%; middle value at least 6.2-fold (0.79 log units) away from the limit.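

Compound 3 is reported only as a limit of the assay, not as a number: the limit of > 100000 nM in this assay, at which 1 of the 3 values shown sits.

Until now the series showed only a single nitro changing position. Here a second nitro is added on an aromatic carbon, and compound 3 carries the nitro of compound 1 and the nitro of compound 2 on one ring. Read from the ring of compound 2, the change gives an at least 8.4-fold higher number from compound 2 to compound 3 (0.92 log units; beyond the scatter), so the lower number of compound 2 in this assay does not survive the added group. Read from the ring of compound 1, the same change gives an at least 1.7-fold higher number from compound 1 to compound 3 (0.25 log units; that floor lies within the scatter), and since that floor lies within the scatter, only the step from compound 2 is established as a real change.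

Going by these compounds, the true size of both steps remains open while compound 3 stands at a limit. Also open, on these data alone, is whether the rise is specific to nitro, since an amine or a carboxylic acid on the same aromatic carbon would test whether any added group there gives a similar step.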